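This account rests on a few compounds, and the source may have more. Where it says the series, first, only, none or still open, it means among the compounds named here.

Compound 1 `Cc1nc(N)sc1CCCN/C(N)=N/C(=O)NCC(C)C1CCCCC1`: 224 nM
Compound 2 `Cc1nc(N)sc1CCCN/C(N)=N/C(=O)NCC(C)CC1CCCCC1`: 302 nM

Going by the values given here, in a functional assay on HEK293T cells for agonist activity at histamine H2 receptor (Homo sapiens), read by beta-arrestin recruitment (a lower number here means that less compound is needed, a higher number that more compound is needed for the effect), compound 2 and compound 1 sit within the scatter of each other; the only measured step, a 1.3-fold higher number from compound 1 to compound 2 (0.13 log units; within the scatter), is too small to signal a trend. Compound 3 `CCCCCNC(=O)/N=C(\N)NCCCc1sc(N)nc1C` differs from compound 2 by butyl in place of 1-(cyclohexylmethyl)ethyl on a saturated chain carbon bound to an amide-type nitrogen. Among the compounds with values here, the one step that bears on it touched the same tail region and left the number essentially unchanged, but no measured pair shows what removing the ring does, so a modest rise is expected with wide uncertainty. The expected step is a 2.3-fold higher number from compound 2 to compound 3 (0.37 log units; beyond the scatter). Compound 3 is estimated at 700 nM, with a range from 150 nM to 3000 nM.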

Compound 3, half-maximal effective concentration: 178 nM
Beside the measured number, compound 3's estimate is 3.9-fold (0.59 log units) above it, within the range that was stated.
By their numbers in this assay, from the lowest: compounds 3, 1 and 2 (each within the scatter of the next).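

In this assay the six-membered ring of the tail proves dispensable among these compounds: butyl in place of 1-(cyclohexylmethyl)ethyl gives a 1.7-fold lower number from compound 2 to compound 3 (0.23 log units; within the scatter) and butyl in place of 1-cyclohexylethyl gives a 1.3-fold lower number from compound 1 to compound 3 (0.10 log units; within the scatter) at this saturated chain carbon bound to an amide-type nitrogen. Losing the ring therefore leaves the number within the scatter, as the earlier cyclohexylmethyl step did. No measurement offered here explains this. On these data alone, whether a longer chain such as octyl or a tail ending in an amine would move the number beyond the scatter remains open.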